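The source may hold more compounds than are shown below. What is called first, only, known or untested is meant among the compounds shown, and "the series" means these compounds.

In an assay on CHO cells for antagonist activity at transient receptor potential cation channel subfamily V member 1 (Homo sapiens), read by FLIPR (on this read-out higher numbers stand for weaker inhibition and lower numbers for stronger inhibition), compound 1 `CC(C)CCSc1cc(C(F)(F)F)ccc1CNC(=O)C(C)c1ccc(NS(C)(=O)=O)c(F)c1` gives 1.4 nM. Compound 2 `CC(C(=O)NCc1ccc(C(F)(F)F)cc1SCCCO)c1ccc(NS(C)(=O)=O)c(F)c1` keeps the same core, yet in this assay compound 2 is reported as "not active" (no number reported), so no number places it against compound 1. Compound 3 `CC(C(=O)NCc1ccc(C(F)(F)F)cc1[N+](=O)[O-])c1ccc(NS(C)(=O)=O)c(F)c1` differs from compound 2 in one place: nitro in place of (3-hydroxypropyl)sulfanyl on an aromatic carbon. Among the compounds with values here, no measured step covers such a change, so its size and direction remain open, and the expectation rests only on the two measured compounds. Compound 3 is expected to give roughly 300 nM, with a wide range from 20 nM to 5000 nM, and it may again yield no number at all.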

Compound 3, inhibition constant: "not active" (no number reported)
Compound 3 has no reported number here; no gap can be computed for the estimate.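

In this assay compound 2 and compound 3 both lack a number, so no step can be read between them. What nitro in place of (3-hydroxypropyl)sulfanyl does to inhibition stays open, and no evidence shown bears on this result.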